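Permeability step from a fluoropyridyl to a chloromethylpyridyl ether

A few compounds are considered here, and "the series" means these few. Any claim that something is new, unique, unknown or untested is made for them only; others in the source may bear on it.

For the measured compounds named here, the pair begins with compound 2 `Cn1c(COc2cccc(C(=O)O)c2)nc2ccc(Oc3ncccc3F)cc21`, which in an ADME assay for permeability, using PAMPA, with a stated time of 4 h (on this read-out lower numbers stand for lower permeability and higher numbers for higher permeability), gives 3.9 10^-6 cm/s, the lowest of the two numbers known here. Going by the values given here, compound 1 `Cn1c(COc2cccc(C(=O)O)c2)nc2ccc(Oc3cc(Cl)ccn3)cc21` gives 10.3 10^-6 cm/s in this assay, and the change a 2.6-fold lower number from compound 1 to compound 2 (0.42 log units; beyond the scatter) is the only measured step that bears on the question. Compound 3 `Cc1cc(Cl)cnc1Oc1ccc2nc(COc3cccc(C(=O)O)c3)n(C)c2c1` differs from compound 2 by 5-chloro-3-methylpyridin-2-yl in place of 3-fluoropyridin-2-yl on an oxygen on an aromatic ring. Since the chloropyridyl ether of compound 1 sat higher than compound 2, a modest upward step is expected, a 3.1-fold higher number from compound 2 to compound 3 (0.49 log units; beyond the scatter). Compound 3 is therefore estimated at 12 10^-6 cm/s, with a range from 5 10^-6 cm/s to 28 10^-6 cm/s.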

Compound 3, apparent permeability: 13.7 10^-6 cm/s
Estimate against measurement, compound 3: 1.1-fold (0.06 log units) below; measured number inside the range.
By their numbers in this assay, from the lowest: compound 2; then compounds 1 and 3 (each within the scatter of the next).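

In this assay, a second group in place of 3-fluoropyridin-2-yl also stands clear of compound 2, with 5-chloro-3-methylpyridin-2-yl on the oxygen (a 3.5-fold higher number from compound 2 to compound 3 (0.55 log units; beyond the scatter)). Compounds 1 and 3 cannot be told apart at this position (a 1.3-fold higher number from compound 1 to compound 3 (0.12 log units; within the scatter)), although their groups differ in the placing of chlorine and in the methyl. Nothing available here accounts for the step from compound 2. The compounds shown leave open how a pyridin-2-yl group carrying only the chlorine or only the methyl would read, and how an amine on this ring would compare.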